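Naphthyl Replaces Methylphenyl on the Thioether Arm

The compounds below may be only part of what the source reports. "The series", "measured", "known", "first", "only" and "open" are said of these compounds alone.

Measured compounds:
compound 1, `C/C(C#Cc1ccccc1)=N\N/C(N)=N/S(=O)(=O)c1cc(C)c(Cl)cc1SCc1ccccc1C`: 270000 nM
compound 2, `C/C(C#Cc1ccccc1)=N\N/C(N)=N/S(=O)(=O)c1cc(C)c(Cl)cc1SCc1cccc(C)c1`: 105000 nM
compound 3, `Cc1cc(S(=O)(=O)/N=C(\N)N/N=C/C#Cc2ccccc2)c(SCc2ccccc2Cl)cc1Cl`: 14000 nM

In a functional assay on HeLa cells (Homo sapiens) for antiproliferative activity, read by MTT assay, with a stated time of 72 h (a lower number here means a stronger inhibitor, a higher number a weaker inhibitor), compound 1 gives the highest of the three numbers and is the weakest inhibitor of the set. Among the measured compounds shown here, its nearest neighbour is compound 2, and the one measured step, a 2.6-fold lower number from compound 1 to compound 2 (0.41 log units; beyond the scatter), moves the number down by a modest amount. Compound 3 stands far lower still, but it differs from compound 1 in more than one place, so its value offers only a loose bearing.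

Compound 4, `C/C(C#Cc1ccccc1)=N\N/C(N)=N/S(=O)(=O)c1cc(C)c(Cl)cc1SCc1cccc2ccccc12`, has not been measured. It differs from compound 1 in one place: naphthalen-1-yl in place of 2-methylphenyl on a saturated chain carbon bound to a sulfur. For the measured compounds named here, the only step that bears on this is the one from compound 1 to compound 2, which also alters the aryl group on the saturated chain carbon bound to a sulfur; it was modest and downward. A change of similar size and direction is therefore expected here, with wide uncertainty, and the estimated step is a 2.3-fold lower number from compound 1 to compound 4 (0.35 log units; beyond the scatter). Compound 4 is estimated at 120000 nM, within a range from 40000 nM to 360000 nM.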

Compound 4, half-maximal inhibitory concentration: 125000 nM
Compound 4: middle estimate off by 1.0-fold (0.02 log units), on the low side; low and high end bracket the measured number.
By their numbers in this assay, from the lowest: compound 3; then compounds 2 and 4 (each within the scatter of the next); then compound 1.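

In this assay, a second fused aromatic ring is accommodated on the saturated chain carbon bound to a sulfur, and replacing 2-methylphenyl with naphthalen-1-yl gives a 2.2-fold lower number from compound 1 to compound 4 (0.33 log units; beyond the scatter). Replacing 3-methylphenyl with naphthalen-1-yl gives a 1.2-fold higher number from compound 2 to compound 4 (0.08 log units; within the scatter), so these two groups cannot be ranked here, and both replacements of 2-methylphenyl shown lower the number by a modest amount. No supporting measurement accounts for this result.

The compounds shown leave open how naphthalen-2-yl or pyridin-3-yl would read at this place. They also leave open whether an amine or a carboxylic acid on the naphthalen-1-yl group would move the number in either direction.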